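The compounds below may be only part of what the source reports. "The series", "measured", "known", "first", "only" and "open" are said of these compounds alone.

Within the data shown here, compound 1 `O=C1O[C@H]([C@@H](O)Cn2cc(-c3ccc(Br)cc3)nn2)C(OCc2ccccc2)=C1OCc1ccccc1` is the only member of the set with a numerical reading: in a functional assay on HepG2 cells (Homo sapiens) for antiproliferative activity, read by MTT assay, with a stated time of 72 h (on this read-out higher numbers stand for weaker inhibition and lower numbers for stronger inhibition), compound 1 gives 5070 nM. Compound 2 `O=C1O/C(=C\Cn2cc(-c3cc(F)cc(F)c3)nn2)C(OCc2ccccc2)=C1OCc1ccccc1` returns only a limit of this assay, > 100000 nM. Compound 3 `CCCCCc1ccc(-c2cn(C/C=C3\OC(=O)C(OCc4ccccc4)=C3OCc3ccccc3)nn2)cc1` likewise returns only a limit, > 100000 nM. Among the measured compounds shown here, the single step between measured compounds, a step that the two limits leave unreadable from compound 2 to compound 3, has no readable size because of the limit of > 100000 nM in this assay, at which 2 of the 3 values shown sit. Compound 4 `CCCCCc1ccc(-c2cn(C[C@H](O)[C@H]3OC(=O)C(OCc4ccccc4)=C3OCc3ccccc3)nn2)cc1` carries pentyl in place of bromo on an aromatic carbon. For the measured compounds named here, no measured step bears on this change, since the aryl exchange from compound 2 to compound 3 lies between two limits. With nothing to anchor a direction, the expectation stays close to compound 1, with wide uncertainty and some chance of a limit. For compound 4 the expected value in this assay is 8000 nM, with a range of 2000 nM to 50000 nM. The expected step is a 1.6-fold higher number from compound 1 to compound 4 (0.20 log units; within the scatter), not beyond the scatter.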

Compound 4, half-maximal inhibitory concentration: 7460 nM
Compound 4: middle estimate off by 1.1-fold (0.03 log units), on the high side; the range from low to high includes it.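

In this assay, this position gives a readable aryl change, a 1.5-fold higher number from compound 1 to compound 4 (0.17 log units; within the scatter), so the result does not separate 4-bromophenyl from 4-pentylphenyl. Pentyl, with 5 heavy atoms, takes the place of bromo, which has 1, without a step beyond the scatter. The earlier aryl exchange could not show this, as neither end gives a number: the limit of > 100000 nM in this assay, at which 2 of the 4 values shown sit.

Still open, from the compounds shown here alone, is how an amine or a carboxylic acid on this aromatic carbon would read. A chain longer than pentyl at the same place also remains untested in the compounds shown.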